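The source may hold more compounds than are shown below. What is called first, only, known or untested is meant among the compounds shown, and "the series" means these compounds.

Compound 1 `O=C(CCCCCCN1C(=O)/C(=N\O)c2cc(Br)ccc21)NO` gives 970 nM in a functional assay on NCI-H460 cells (Homo sapiens) for antiproliferative activity, read by sulforhodamine B assay, with a stated time of 48 h; on this read-out higher numbers stand for weaker inhibition and lower numbers for stronger inhibition. Compound 2 `Cc1ccc2c(c1)/C(=N/O)C(=O)N2CCCCCCC(=O)NO`, which carries methyl in place of bromo on an aromatic carbon, gives 2090 nM in this assay; that change produced a 2.2-fold higher number from compound 1 to compound 2 (0.33 log units; beyond the scatter). Compound 3 `CO/N=C1/C(=O)N(CCCCCCC(=O)NO)c2ccc(Br)cc21` gives 2900 nM in this assay; how its core differs from the core of compound 1 is not broken down here. Going by the values given here, compound 4 `CO/N=C1/C(=O)N(CCCCCCC(=O)NO)c2ccc(C)cc21` is unmeasured; relative to compound 3 it carries methyl in place of bromo on an aromatic carbon, the same change as the one from compound 1 to compound 2, at the same place. Because the earlier change gave a 2.2-fold higher number from compound 1 to compound 2 (0.33 log units; beyond the scatter), a comparable step is expected here, giving a 2.1-fold higher number from compound 3 to compound 4 (0.32 log units; beyond the scatter) in this assay. Compound 4 is therefore estimated at 6000 nM in this assay, most likely between 2500 nM and 14000 nM.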

Compound 4, half-maximal inhibitory concentration: 1190 nM
Beside the measured number, compound 4's estimate is 5.0-fold (0.70 log units) above it; measured number outside the range, below it.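

In this assay, methyl in place of bromo gave a 2.4-fold lower number from compound 3 to compound 4 (0.39 log units; beyond the scatter), a step in the opposite direction to the earlier one. The two steps therefore disagree: the same change on two cores in this assay, a 2.2-fold higher number (0.33 log units; beyond the scatter) from compound 1 to compound 2 and a 2.4-fold lower number (0.39 log units; beyond the scatter) from compound 3 to compound 4, 5.3-fold (0.72 log units) apart, beyond the scatter of two such steps. This shows that, among these compounds, the size and direction of the step seen on the core of compound 1 do not carry over to the core of compound 3, but two pairs cannot show what underlies the reversal or predict the step on any further core.

The compounds shown leave open whether chloro or methoxy in the same place would follow the pair with compound 1 or the pair with compound 3. They also leave open whether either step would persist with a shorter chain.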